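Adding a Second Hydroxy to a Five-Ring Scaffold

The source may report more compounds than this note shows. Statements on the series, on what has been measured and on what is new or still open speak of the compounds shown alone.

Of the compounds shown here, three built on a shared core have been measured. Compound 1 `Oc1ccc2cc1Oc1ccc(cc1)CCc1cccc(O)c1Oc1ccc(cc1)CC2` in a functional assay on K562 cells (Homo sapiens) for antiproliferative activity, read by MTT assay, with a stated time of 48 h (on this read-out lower numbers stand for stronger inhibition and higher numbers for weaker inhibition), gives 8520 nM. Compound 2 `Oc1ccc2cc1Oc1ccc(cc1)CCc1cccc(O)c1Oc1ccc(cc1O)CC2` differs from it by hydroxy in place of hydrogen on an aromatic carbon. In this assay compound 2 gives 24900 nM, and a 2.9-fold higher number from compound 1 to compound 2 (0.47 log units; beyond the scatter). Compound 3 `Oc1ccc2cc1Oc1ccc(cc1)CCc1ccc(O)c(c1)Oc1ccc(cc1)CC2` has the same atoms as compound 1 joined differently; the difference between the two cores is not broken down here. In this assay compound 3 gives 10300 nM, a number close to that of compound 1 and within the usual scatter of it. Compound 4 `Oc1ccc2cc1Oc1ccc(cc1)CCc1ccc(O)c(c1)Oc1ccc(cc1O)CC2` stands to compound 3 as compound 2 stands to compound 1, the change being (hydroxy in place of hydrogen on an aromatic carbon). The place of the entering hydroxy is described in the same words for both pairs, so this is the same change. For compound 4 the expected step is a 2.7-fold higher number from compound 3 to compound 4 (0.43 log units; beyond the scatter), set beside the earlier one, and it rests on the measured pair because a 2.9-fold higher number from compound 1 to compound 2 (0.47 log units; beyond the scatter). Among the compounds with values here, only one measured pair supports this, so the range is kept wide. Compound 4 is therefore estimated at 28000 nM in this assay, between 12000 nM and 65000 nM.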

Compound 4, half-maximal inhibitory concentration: 15600 nM
Beside the measured number, compound 4's estimate is 1.8-fold (0.25 log units) above it, within the range that was stated.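

In this assay, the hydroxy in place of hydrogen on an aromatic carbon gives a 1.5-fold higher number from compound 3 to compound 4 (0.18 log units; within the scatter). Set beside the same change on the core of compound 1, this step does not differ from the earlier one by more than repeated measurements of two such steps could: the same change on two cores in this assay, a 2.9-fold higher number (0.47 log units; beyond the scatter) from compound 1 to compound 2 and a 1.5-fold higher number (0.18 log units; within the scatter) from compound 3 to compound 4, 1.9-fold (0.29 log units) apart, within the scatter of two such steps This does not show that the change does exactly the same thing on both cores: only the earlier step is beyond the scatter, the new one cannot be told from no change at all, and two pairs are too few to make a rule for the series.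

The compounds shown hold only a hydroxy at this place, so it remains open how a methoxy, an amine or a carboxylic acid there would compare. On these data alone, it also remains open whether the change would carry over in the same way to any core other than these two.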